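The source may report more compounds than this note shows. Statements on the series, on what has been measured and on what is new or still open speak of the compounds shown alone.

In a functional assay on NALM-6 cells (Homo sapiens) for cytotoxicity, read by luminescence and CellTiter-Glo, with a stated time of 3 days (a lower number here means a stronger inhibitor, a higher number a weaker inhibitor), compound 1 `O=C(Nc1ccc(C(F)(F)F)cc1)c1cc(Cl)ccc1O` gives 1210 nM. Compound 2 `O=C(Nc1ccc(C(F)(F)F)cc1)c1cc(F)ccc1O` gives 2090 nM and compound 3 `O=C(Nc1ccc(C(F)(F)F)cc1)c1cc(Br)ccc1O` gives 1090 nM, so compound 1 stands among three values that all lie within the scatter of one another. Compound 4 `O=C(Nc1ccc(C(F)(F)F)c(Cl)c1)c1cc(Cl)ccc1O` differs from compound 1 as follows: chloro in place of hydrogen on an aromatic carbon. This is chloro in place of hydrogen on an aromatic carbon, ortho to a trifluoromethyl group. The measured steps exchange one halogen for another at a different place, and they bear on this change only indirectly: a 1.7-fold higher number from compound 1 to compound 2 (0.24 log units; within the scatter), a 1.1-fold lower number from compound 1 to compound 3 (0.05 log units; within the scatter) and a 1.9-fold lower number from compound 2 to compound 3 (0.28 log units; within the scatter). None of them leaves the scatter, so no step beyond the scatter is expected in this assay, and no firm direction. The expected step is a 1.3-fold lower number from compound 1 to compound 4 (0.13 log units; within the scatter). Compound 4 is estimated at 900 nM, with an expected range from 350 nM to 2300 nM.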

Compound 4, half-maximal inhibitory concentration: 1220 nM
Beside the measured number, compound 4's estimate is 1.4-fold (0.13 log units) below it; the range from low to high includes it.
By their numbers in this assay, from the lowest: compounds 3, 1, 4 and 2 (each within the scatter of the next).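

Earlier steps only exchanged one halogen for another at a different place, whereas chloro in place of hydrogen, ortho to a trifluoromethyl group, fills a position that carries only hydrogen in compound 1. In this assay this gives a 1.0-fold higher number from compound 1 to compound 4 (0.00 log units; within the scatter) and so shows that this position accepts a chlorine atom without a step beyond the scatter. No measurement shown here offers an explanation for this result. The compounds shown leave open whether an amine, a methoxy group or a carboxylic acid at this position would also stay within the scatter. They also leave open whether this chloro would give the same result with fluoro or bromo in place of the chloro of compound 1.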